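A few compounds are considered here, and "the series" means these few. Any claim that something is new, unique, unknown or untested is made for them only; others in the source may bear on it.

The measured compounds in a physicochemical assay for lipophilicity, read by HPLC, in phosphate buffer, measured as octanol-water partition, with a stated time of 24 h, at pH 7.4; on this read-out lower numbers stand for lower lipophilicity and higher numbers for higher lipophilicity:

Compound 1, `Clc1ccc2c(NCCCCCCCCCCNc3nccc(Cl)n3)ccnc2c1`: 1.99
Compound 2, `Clc1ccc2c(NCCCCCCCCNc3ccnc(Cl)n3)ccnc2c1`: 1.48

Among the compounds with values here, compound 1 has the higher of the two numbers; the only measured step, a number 0.51 log units lower from compound 1 to compound 2 (beyond the scatter), moves from it downward, beyond the scatter. Compound 3, `Clc1ccc2c(NCCCCCCCCCCCCNc3nccc(Cl)n3)ccnc2c1`, shares the core of compound 1 and differs from it in one place: 2-((4-chloropyrimidin-2-yl)amino)ethyl in place of (4-chloropyrimidin-2-yl)amino on a saturated chain carbon, ten or more bonds along the chain from a nitrogen on an aromatic ring. Within the data shown here, the one measured step bears on this only loosely, since the change from compound 1 to compound 2 also alters where the chain meets the chloropyrimidine, but its size, a number 0.51 log units lower from compound 1 to compound 2 (beyond the scatter), shows that a shorter link between the two aromatic amines went with a lower number. Lengthening the link, as in compound 3, is therefore expected to move the number the other way, by a step of comparable or somewhat larger size. For compound 3 in this assay the estimate is 2.7, within 2.2 to 3.3, which means an expected step of a number 0.71 log units higher from compound 1 to compound 3 (beyond the scatter).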

Compound 3, distribution coefficient: 2.59
The estimate for compound 3 lay 0.11 log units above the measured number; measured number inside the range.
By their numbers in this assay, from the lowest: compound 2; then compound 1; then compound 3.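

In this assay, 2-((4-chloropyrimidin-2-yl)amino)ethyl in place of (4-chloropyrimidin-2-yl)amino on a saturated chain carbon gives a number 0.60 log units higher from compound 1 to compound 3 (beyond the scatter). Unlike a number 0.51 log units lower from compound 1 to compound 2 (beyond the scatter), where (2-chloropyrimidin-4-yl)amino is the group that ends the chain, this step keeps the 4-chloropyrimidin-2-yl group: the entering group has 10 heavy atoms against 8 and 6 carbon against 4, with the same nitrogen and chlorine counts, the same six-membered aromatic ring with 2 hetero atoms and the same hydrogen-bond donor and acceptor counts, so the number is here seen to move with chain length while that end stays the same. Nothing in hand accounts for the size of this rise, and no measurement explains it.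

The compounds shown leave open how much of the earlier fall belongs to the shorter chain and how much to the (2-chloropyrimidin-4-yl)amino group, which a chain of the length in compound 2 ending in (4-chloropyrimidin-2-yl)amino would separate. They also leave open whether a still longer chain would carry the number further in the same direction, and what an amine or an ether oxygen placed within the chain would do to it.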